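Naphthyl-pyridine series: amide to carboxylic acid on the chain

The source may hold more compounds than are shown below. What is called first, only, known or untested is meant among the compounds shown, and "the series" means these compounds.

Measured so far:
compound 1 `CNC(=O)CCc1ccncc1-c1ccc2ccccc2c1` gives 100%
compound 2 `NC(=O)/C=C/c1ccncc1-c1ccc2ccccc2c1` gives 102%

Both values come from an assay on a protein complex for inhibition of CDK8/Cyclin C (Homo sapiens), with a stated time of 1 h, tested at 10 uM; a higher number here means more inhibition at the concentration tested (going by the name of the read-out), a lower number less inhibition. In this assay compound 2 stands highest of the two numbers, but the nearest value, that of compound 1, lies within the scatter, so the two are not distinguished. Within the data shown here, the one measured step, a number 2 percentage points higher from compound 1 to compound 2 (within the scatter), is the only comparison that bears on the change in hand. Compound 3 `O=C(O)CCc1ccncc1-c1ccc2ccccc2c1` differs from compound 2 as 2-carboxyethyl in place of 2-carbamoylethenyl on an aromatic carbon. With both measured numbers near the top of the read-out and no step beyond the scatter, a small loss at most is expected for compound 3, as a number 12 percentage points lower from compound 2 to compound 3 (beyond the scatter). The estimate for compound 3 in this assay is 90%, ranging from 60% to 105%.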

Compound 3, a percentage reported as inhibition, at one concentration (the size of the read-out at that concentration, not a potency): 101%
For compound 3 the middle estimate is 11 percentage points below the measured one; the range from low to high includes it.
By their numbers in this assay, from the lowest: compounds 1, 3 and 2 (each within the scatter of the next).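

In this assay this position accepts a carboxylic acid at the chain end: the change to 2-carboxyethyl gives a number 1 percentage points lower from compound 2 to compound 3 (within the scatter) and hydroxy in place of methylamino on the carbonyl carbon gives a number 1 percentage points higher from compound 1 to compound 3 (within the scatter) at the concentration tested. Neither the end group nor the chain change separates the compounds here. No measurement shown accounts for this result.

On these data alone, whether an amine or a longer chain at this position would lower the number remains open. A single concentration also gives no potency order for compound 1, compound 2 and compound 3.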